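Substitution on the amine nitrogen: compound 2 to compound 3

A few compounds are considered here, and "the series" means these few. Any claim that something is new, unique, unknown or untested is made for them only; others in the source may bear on it.

In a functional assay on the whole organism with Rattus norvegicus as the target (a higher number here means that more compound is needed for the effect, a lower number that less compound is needed), compound 1 `CC1CCC(=NNc2ccccn2)c2ncc(C(=O)O)c(=O)n21` gives only a limit, > 100 umol/kg. Compound 2 `CNN=C1CCC(C)n2c1ncc(C(=O)O)c2=O` likewise gives only a limit in this assay, > 100 umol/kg. Going by the values given here, the single measured step, a step that the two limits leave unreadable from compound 1 to compound 2, is therefore unreadable in size; both values sit at the limit of > 100 umol/kg in this assay, at which 2 of the 2 values shown sit. Compound 3 `CC1CCC(=NN(C)c2ccccc2)c2ncc(C(=O)O)c(=O)n21` differs from compound 2 by phenyl in place of hydrogen on an amine nitrogen. Among the compounds with values here, no measured step bears on this change, so neither size nor direction can be read for it, and compound 2 offers no number to anchor on. Compound 3 is expected to remain near the limit in this assay, estimated at 150 umol/kg within 40 umol/kg to 600 umol/kg, meaning an expected step that the limit leaves unreadable from compound 2 to compound 3.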

Compound 3, dose for 50% inhibition: > 100 umol/kg
Compound 3: no number, only a limit (the forecaster's own chance of this, stated with the estimate: 70%); the middle value does not contradict the limit.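

Compound 3 gives only a limit, as do compound 1 and compound 2, so no step among these compounds can be read: the limit of > 100 umol/kg in this assay, at which 3 of the 3 values shown sit. The compounds shown leave open whether any substituent on the amine nitrogen changes the dose needed in this assay.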